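A few compounds are considered here, and "the series" means these few. Any claim that something is new, unique, unknown or untested is made for them only; others in the source may bear on it.

Measured so far in an ADME assay on NIH3T3 cells (Mus musculus) for cytotoxicity; a higher number here means that more compound is needed for the effect, a lower number that less compound is needed:
Compound 1 `Cc1cc(Oc2cccc(Cn3cnnc3)c2)cc(C)c1Cl`: > 100000 nM (a limit, not a number)
Compound 2 `Cc1nnc(-c2cccc(Oc3cc(C)c(Cl)c(C)c3)c2)o1`: 46100 nM

Going by the values given here, compound 2, at 46100 nM, holds the only actual number in this assay so far. Compound 1 stands at > 100000 nM, which is a limit of the assay.

The next compound is compound 3 `Cc1nnc(Cc2cccc(Oc3cc(C)c(Cl)c(C)c3)c2)o1`, which differs from compound 2 in one place: (5-methyl-1,3,4-oxadiazol-2-yl)methyl in place of 5-methyl-1,3,4-oxadiazol-2-yl on an aromatic carbon. Here (5-methyl-1,3,4-oxadiazol-2-yl)methyl takes the place of 5-methyl-1,3,4-oxadiazol-2-yl on an aromatic carbon.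

Among the compounds with values here, one measured step bears on this: an at least 2.1-fold lower number from compound 1 to compound 2 (0.33 log units; beyond the scatter). In that step, the ring and its methyl link changed together, so it cannot show what either change does alone. Compound 3 keeps the ring of compound 2 and gains a methyl link of the kind compound 1 also carries. Starting from compound 2 at 46100 nM, a slight move toward higher numbers is therefore expected. The expected change is a 1.3-fold higher number from compound 2 to compound 3 (0.11 log units; within the scatter), which would not be a clear step beyond the scatter. Compound 3 is estimated at 60000 nM, with an expected range of 25000 nM to 100000 nM.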

Compound 3, half-maximal effective concentration: 6200 nM
Compound 3: the middle estimate sits 9.7-fold (0.99 log units) above what was measured; measured number below the stated range.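

In this assay, the position on the aromatic carbon meta to a large group proves sensitive to a very small change: with the 5-methyl-1,3,4-oxadiazol-2-yl ring kept, adding only the methyl link gives a 7.4-fold lower number from compound 2 to compound 3 (0.87 log units; beyond the scatter). The earlier comparison changed the ring and the link together, whereas this step isolates the link and shows that it moves the number downward, so less compound is needed for the cytotoxic effect. With the methyl link held constant, exchanging the ring gives an at least 16-fold lower number from compound 1 to compound 3 (1.20 log units; beyond the scatter), although this step rests on compound 1, whose value is a limit of the assay and not a number, so its true size stays open: the limit of > 100000 nM in this assay, at which 1 of the 3 values shown sits.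

As far as these compounds go, whether the downward move would continue with a longer chain, such as an ethyl link, remains open, as does the effect of an amine placed on the methyl link. The compounds shown also cannot say why the methyl link has this effect, or whether it would have the same effect with a ring other than the 5-methyl-1,3,4-oxadiazol-2-yl.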